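The source may hold more compounds than are shown below. What is called first, only, known or untested is meant among the compounds shown, and "the series" means these compounds.

Compound 3 `Cc1nc(-c2cccc(O)c2)c(C(=O)N2CCN(c3cccc(Cl)c3)CC2)o1` carries a 3-hydroxyphenyl on the shared core. In a functional assay on HL-60 cells (Homo sapiens) for inhibition, read by MTT assay, with a stated time of 72 h (on this read-out lower numbers stand for stronger inhibition and higher numbers for weaker inhibition), compound 3 gives 105 nM. Compound 2 `COc1cc(-c2nc(C)oc2C(=O)N2CCN(c3cccc(Cl)c3)CC2)ccc1O` differs from compound 3 only in that ring: 4-hydroxy-3-methoxyphenyl in place of 3-hydroxyphenyl on an aromatic carbon. In this assay compound 2 gives 85.9 nM, and the step of a 1.2-fold higher number from compound 2 to compound 3 (0.09 log units; within the scatter), so these two stand together. Compound 1 `Cc1nc(-c2cccc(OP(=O)(O)O)c2)c(C(=O)N2CCN(c3cccc(Cl)c3)CC2)o1` is compound 3 with one further change, (a group of 4 heavy atoms (3 oxygen, 1 phosphorus; no ring) in place of a hydrogen atom, on an oxygen on an aromatic ring). For compound 1 the result in this assay is a limit of the assay, > 1000 nM, and not a measured number. The step of an at least 9.5-fold higher number from compound 3 to compound 1 (0.97 log units; beyond the scatter), the value of compound 1 resting on (the limit of > 1000 nM in this assay, at which 1 of the 3 values shown sits). Compound 4 `COc1cc(-c2nc(C)oc2C(=O)N2CCN(c3cccc(Cl)c3)CC2)ccc1OP(=O)(O)O` has not yet been measured. It stands to compound 2 as compound 1 stands to compound 3, carrying (a group of 4 heavy atoms (3 oxygen, 1 phosphorus; no ring) in place of a hydrogen atom, on an oxygen on an aromatic ring). The place of this change is the same in both pairs, word for word, so it is the same change made on a core that differs only by the ring just described. Because the earlier step was an at least 9.5-fold higher number from compound 3 to compound 1 (0.97 log units; beyond the scatter), the step of a 17-fold higher number from compound 2 to compound 4 (1.24 log units; beyond the scatter) is expected to be of a similar size, although with a single example this expectation is held loosely. Compound 4 is therefore estimated at 1500 nM in this assay, with the plausible range running from 400 nM to 6000 nM and a real chance that only a limit is reported.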

Compound 4, half-maximal inhibitory concentration: 303 nM
Estimate against measurement, compound 4: 5.0-fold (0.69 log units) above; the measured number lies below the stated range.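

In this assay, adding the group of 4 heavy atoms (3 oxygen, 1 phosphorus) to the oxygen on the aromatic ring again moves the result towards weaker inhibition, with a 3.5-fold higher number from compound 2 to compound 4 (0.55 log units; beyond the scatter). The direction of the change therefore holds on both cores shown, but its size does not carry over unchanged from one core to the other: the same change on two cores in this assay, an at least 9.5-fold higher number (0.97 log units; beyond the scatter) from compound 3 to compound 1 and a 3.5-fold higher number (0.55 log units; beyond the scatter) from compound 2 to compound 4, at least 2.6-fold (0.43 log units) apart, beyond the scatter of two such steps This rests on only two pairs, and the result for compound 1 is a limit and not a measured number, so the data give no exact size for the gap and do not show how the change would behave on a third core: the limit of > 1000 nM in this assay, at which 1 of the 4 values shown sits.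

The compounds shown have only a hydrogen atom or this one group on that oxygen, so it remains open whether a methyl group, an acetyl group or a short chain ending in a carboxylic acid or an amine would give a similar step. Going by these compounds, it is also open whether the difference between the two steps comes from the methoxy group, the shift of the hydroxy group around the ring, or both, since compound 2 and compound 3 differ in the ring as a whole.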